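This account rests on a few compounds, and the source may have more. Where it says the series, first, only, none or still open, it means among the compounds named here.

Measured in a functional assay on PBMC cells (Homo sapiens) for inhibition, with a stated time of 24 h; on this read-out lower numbers stand for stronger inhibition and higher numbers for weaker inhibition:
- Compound 1 `NCC1(c2cccc(-c3ccnc4[nH]ncc34)c2)CCC1`: 300 nM
- Compound 2 `NCC1(c2cccc(-c3ccnc4[nH]ncc34)c2)CCCC1`: 350 nM

For the measured compounds named here, the two measured compounds stand level, so compound 1 sits alongside the only other number available, with no order between them. Going by the values given here, the one measured step is a 1.2-fold higher number from compound 1 to compound 2 (0.07 log units; within the scatter), and it replaces 1-(aminomethyl)cyclobutyl with 1-(aminomethyl)cyclopentyl on an aromatic carbon.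

Compound 3 `NCC1(c2cccc(-c3ccnc4[nH]nc(C(F)(F)F)c34)c2)CCC1` keeps the 1-(aminomethyl)cyclobutyl group of compound 1 and changes the molecule elsewhere: trifluoromethyl in place of hydrogen on an aromatic carbon. This places trifluoromethyl in place of hydrogen on an aromatic carbon, at a place that the measured step does not touch. That step therefore bears on this change only weakly. Among the compounds with values here, no measured compound carries any group other than hydrogen at this place, so the data give neither a direction nor a size for the change in this assay. The expectation stays centred on compound 1, with a wide margin on both sides.

The estimated step is no change at the digits printed from compound 1 to compound 3 (within the scatter). For compound 3 the expected value is 300 nM, with an estimated range from 70 nM to 1300 nM.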

Compound 3, half-maximal inhibitory concentration: 90 nM
For compound 3 the middle estimate is 3.3-fold (0.52 log units) above the measured one; measured number inside the range.
By their numbers in this assay, from the lowest: compound 3; then compounds 1 and 2 (each within the scatter of the next).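

Read in this assay, this is the first group other than hydrogen at this place, and it fixes both a direction and a size for the change: a 3.3-fold lower number from compound 1 to compound 3 (0.52 log units; beyond the scatter). The aromatic carbon next to the ring nitrogen thus accepts trifluoromethyl, with its 4 heavy atoms, without loss of inhibition, and this is the first change among these compounds to separate two of them beyond the scatter, as the earlier exchange of 1-(aminomethyl)cyclobutyl for 1-(aminomethyl)cyclopentyl did not. Nothing available offers a measured reason for the lower number.

The compounds shown leave open whether this step belongs to trifluoromethyl in particular or would also appear with a methyl group, a chlorine atom, a nitrile or an amine on the same carbon. They also leave open whether the same exchange would give a step of similar size on the 1-(aminomethyl)cyclopentyl compound, compound 2, where only the hydrogen form appears here.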